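The source may hold more compounds than are shown below. What is called first, only, known or untested is meant among the compounds shown, and "the series" means these compounds.

Measured so far:
compound 1, `O=C(C1CCC(F)(F)CC1)N1CC(c2nc(-c3cccc(F)c3)no2)C1` – in an assay on HEK293 cells for negative allosteric modulation of metabotropic glutamate receptor 5 (Homo sapiens), read by FLIPR (on this read-out higher numbers stand for weaker inhibition and lower numbers for stronger inhibition), compound 1 gives > 10000 nM, which is a limit of the assay and not a number
compound 2, `CC1CCCC(C(=O)N2CC(c3nc(-c4cccc(Cl)c4)no3)C2)C1` – in this assay compound 2 gives > 10000 nM, again a limit of the assay and not a number

Within the data shown here, compound 2 therefore stands exactly where the one other value shown stands: both results sit at the limit of > 10000 nM in this assay, at which 2 of the 2 values shown sit, so neither compound inhibited the receptor strongly enough for a number to be read, and nothing can be said about which of the two is the more active. Compound 3, `CC1CCC(C(=O)N2CC(c3nc(-c4cccc(Cl)c4)no3)C2)CC1`, has not yet been measured. It has the same atoms as compound 2, joined differently: 4-methylcyclohexyl in place of 3-methylcyclohexyl on a carbonyl carbon. Among the measured compounds shown here, no step between two measured compounds is available here, so there is no measured guide to what moving the methyl group around the ring does to inhibition. For the measured compounds named here, the only anchor is that compound 2 gives a limit, > 10000 nM. On that basis compound 3 is expected to give about 15000 nM, within a range of 4000 nM to 60000 nM, most probably again only a limit. The expected step is a step that the limit leaves unreadable from compound 2 to compound 3, that is, none beyond the scatter.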

Compound 3, half-maximal inhibitory concentration: > 10000 nM
Compound 3: no number, only a limit (the forecaster's own chance of this, stated with the estimate: 85%); the middle value is on the limit's open side.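

In this assay compound 3 gives > 10000 nM, which is a limit of the assay and not a number. Compound 2 gives a limit too, so no step can be read between compound 2 and compound 3. The compounds shown leave open whether moving the methyl group on the cyclohexyl ring changes inhibition at all, as every result is a limit: the limit of > 10000 nM in this assay, at which 3 of the 3 values shown sit.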